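Methoxy addition on the aryl ring of compound 3

The compounds below may be only part of what the source reports. "The series", "measured", "known", "first", "only" and "open" are said of these compounds alone.

Measured so far:
compound 1 `c1cc(CC2CCCNC2)c2occc2c1` — 95000 nM
compound 2 `N=C(N)N1CCCC(Cc2cccc3ccoc23)C1` — 2800 nM
compound 3 `CC(C)c1nc(N)n2c1CCC(Cc1ccccc1F)C2` — 7900 nM

In an assay for inhibition of Polycomb protein EED (Homo sapiens), read by LC-MS, with a stated time of 2 h (on this read-out lower numbers stand for stronger inhibition and higher numbers for weaker inhibition), compound 3 gives 7900 nM, which is a higher number than compound 2 at 2800 nM and a lower number than compound 1 at 95000 nM; compound 3 thus sits second highest among the three numbers, with compound 2 nearest and compound 1 furthest.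

Compound 4 `COc1ccc(F)c(CC2CCc3c(C(C)C)nc(N)n3C2)c1` differs from compound 3 by methoxy in place of hydrogen on an aromatic carbon. For the measured compounds named here, the only measured step in the set, a 34-fold lower number from compound 1 to compound 2 (1.53 log units; beyond the scatter), concerns a change on an amine nitrogen in a ring of the core of compound 1 and does not bear on a methoxy placed on an aromatic carbon of the pendant ring; no measured pair shows what such a substitution does here. Without a comparable step, the expectation for compound 4 in this assay is a change no larger than the scatter, in either direction, so a 1.3-fold lower number from compound 3 to compound 4 (0.12 log units; within the scatter) is expected. The estimate for compound 4 is therefore 6000 nM, with a range from 2500 nM to 15000 nM.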

Compound 4, half-maximal inhibitory concentration: 1300 nM
Beside the measured number, compound 4's estimate is 4.6-fold (0.66 log units) above it, and the stated range ends above it.
By their numbers in this assay, from the lowest: compound 4; then compound 2; then compound 3; then compound 1.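

In this assay, methoxy in place of hydrogen on an aromatic carbon, meta to a large group and para to a fluoro group, gives a 6.1-fold lower number from compound 3 to compound 4 (0.78 log units; beyond the scatter). For the compounds shown here, this is the first measured change on this six-membered aromatic ring, and it shows that this carbon accepts a group of two heavy atoms with a lower number; the only earlier step, a 34-fold lower number from compound 1 to compound 2 (1.53 log units; beyond the scatter), concerned an amine nitrogen in a ring. Nothing available accounts for the lower number seen with methoxy at this carbon.

Going by these compounds, it remains open whether a hydroxy group, an amine or a longer chain such as ethoxy at the same carbon would give a similar step. A single pair also leaves open whether the methoxy step holds on a ring without the fluoro group.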